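A few compounds are considered here, and "the series" means these few. Any claim that something is new, unique, unknown or untested is made for them only; others in the source may bear on it.

Among the measured compounds shown here, in an ADME assay on BHK-21 cells (Mesocricetus auratus) for cytotoxicity, read by MTT assay (a higher number here means that more compound is tolerated, a lower number that less compound is tolerated), compound 3 (`C/C(=N\NC(N)=S)c1ccc2[nH]c(-c3ccccc3)nc2c1`) gives 32000 nM as the only true number among the compounds tested so far. Compound 1 (`CC(=O)c1ccc2[nH]c(-c3ccc(C(F)(F)F)cc3)nc2c1`) gives > 100000 nM and this is a limit of the assay, not a number. For compound 2 (`C/C(=N\O)c1ccc2[nH]c(-c3ccc(C(F)(F)F)cc3)nc2c1`) the result reads "not determined" (no result reported) and so adds nothing here.

Compound 4 (`C/C(=N\NC(N)=S)c1ccc2[nH]c(-c3ccc(C(F)(F)F)cc3)nc2c1`) differs from compound 3 in one place: trifluoromethyl in place of hydrogen on an aromatic carbon, para to a large group (trifluoromethyl in place of hydrogen on an aromatic carbon). For the measured compounds named here, no measured pair of compounds shows what this swap alone does in this assay so its size must be judged without a direct example. Compound 1 carries the same trifluoromethyl but also differs elsewhere, so it cannot settle the matter. The expectation is therefore no step beyond the usual scatter, with compound 3 at 32000 nM as the starting point. The estimated change, a 1.3-fold lower number from compound 3 to compound 4 (0.11 log units; within the scatter), is correspondingly small. Compound 4 is expected at 25000 nM in this assay with an estimated range from 8000 nM to 80000 nM as the likely outcome.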

Compound 4, half-maximal cytotoxic concentration: 5000 nM
Beside the measured number, compound 4's estimate is 5.0-fold (0.70 log units) above it, outside the stated range (below it).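

In this assay, among the compounds shown here, trifluoromethyl on this aromatic carbon, para to a large group, proves to be far from a neutral swap: the change gives a 6.4-fold lower number from compound 3 to compound 4 (0.81 log units; beyond the scatter), the first direct reading of it. With trifluoromethyl held in place, the other end of the molecule matters too, as exchanging the smaller group on the aromatic carbon for the larger one gives an at least 20-fold lower number from compound 1 to compound 4 (1.30 log units; beyond the scatter). The true size of that second step is unknown, since it starts from a limit of the assay and not a number: the limit of > 100000 nM in this assay, at which 1 of the 4 values shown sits.

On these data alone, the trifluoromethyl swap rests on a single pair, so it remains open whether it would have the same effect with a different group at the other end of the molecule. The compounds shown also leave open what a methyl group, a chlorine atom or an amine would do at the same place.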